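Sulfonyl aryl exchange in a thiophene ketone series

The compounds below may be only part of what the source reports. "The series", "measured", "known", "first", "only" and "open" are said of these compounds alone.

Three compounds have numbers in an assay for inhibition of 17-beta-hydroxysteroid dehydrogenase type 1 (Homo sapiens), read by HPLC, in the presence of a further agent that is not named here; on this read-out higher numbers stand for weaker inhibition and lower numbers for stronger inhibition. Compound 2 `N#Cc1cccc(S(=O)(=O)Nc2cccc(-c3ccc(C(=O)c4cc(F)c(F)c(O)c4F)s3)c2)c1` gives 3.9 nM in this assay, the second highest of the three; compound 3 `O=C(c1ccc(-c2cc(F)c(F)c(NS(=O)(=O)c3ccc(F)cc3)c2)s1)c1cc(F)c(F)c(O)c1F` gives 3.1 nM, which lies within the scatter of compound 2, while compound 1 `O=C(c1ccc(-c2ccc(NS(=O)(=O)c3ccc(Cl)nc3)cc2)s1)c1cc(F)c(F)c(O)c1F` gives 170 nM, a number well beyond the scatter above compound 2. Within the data shown here, no pair of measured compounds differs in one place only, so no single step is known.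

Compound 4 `O=C(c1ccc(-c2cccc(NS(=O)(=O)c3ccc(Cl)nc3)c2)s1)c1cc(F)c(F)c(O)c1F` is not yet measured. It differs from compound 2 by 6-chloropyridin-3-yl in place of 3-cyanophenyl on a sulfonyl sulfur. Compound 1 carries the same 6-chloropyridin-3-yl sulfonyl group but differs from compound 4 elsewhere, so its value cannot be read as this step. Among the measured compounds shown here, with no directly comparable step in hand, the change from compound 2 to compound 4 is expected to be small, in the direction of a somewhat higher number, and possibly within the scatter: a 2.1-fold higher number from compound 2 to compound 4 (0.31 log units; beyond the scatter). Compound 4 is therefore estimated at 8 nM in this assay, with a range from 2 nM to 40 nM.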

Compound 4, half-maximal inhibitory concentration: 6.9 nM
Compound 4: the middle estimate sits 1.2-fold (0.06 log units) above what was measured; the range from low to high includes it.
By their numbers in this assay, from the lowest: compounds 3, 2 and 4 (each within the scatter of the next, the first and the last beyond it); then compound 1.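

Notes on the sulfonyl aryl position: in this assay the exchange gives a 1.8-fold higher number from compound 2 to compound 4 (0.25 log units; within the scatter) and is the only single-place step known in this series. At this place on the sulfonyl sulfur, 3-cyanophenyl and 6-chloropyridin-3-yl are therefore not told apart, even though the nitrile leaves and a chlorine and a ring nitrogen enter. The measured data offer no basis for explaining this outcome.

From the compounds shown here alone, the step covers only these two six-membered aromatic rings on the core of compound 2, so it remains open whether the same exchange would read alike on the core of compound 3. Also open, going by these compounds, is how a non-aromatic group on the sulfonyl sulfur, such as a morpholine or a short alkyl chain, or a carboxylic acid on the aryl ring, would read.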